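The source may hold more compounds than are shown below. What is called first, only, known or untested is meant among the compounds shown, and "the series" means these compounds.

Compound 1 `CN(c1cccc(C#Cc2cc(Cl)ccc2OCC(=O)O)c1)S(C)(=O)=O` is the weaker of the two measured compounds in this set: in an assay on CHO cells for displacement of a labelled ligand from prostaglandin D2 receptor 2 (Homo sapiens), read by scintillation counting (on this read-out higher numbers stand for weaker inhibition and lower numbers for stronger inhibition), compound 1 gives 122 nM, the higher of the two numbers. Compound 2 `CN(C)S(=O)(=O)c1cncc(C#Cc2cc(Cl)ccc2OCC(=O)O)c1`, which shares the chloro-substituted oxyacetic acid side and the alkyne link but carries a different aromatic ring and substituent, gives 37 nM in this assay, a lower number that falls beyond the usual scatter. Within the data shown here, no pair among the measured compounds differs in one place only, so no single-point step is available as a guide.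

Compound 3 `CS(=O)(=O)Cc1cccc(C#Cc2cc(Cl)ccc2OCC(=O)O)c1` differs from compound 1 by (methylsulfonyl)methyl in place of methyl(methylsulfonyl)amino on an aromatic carbon. Among the measured compounds shown here, with no measured step of this kind to lean on, the change is expected to shift the inhibition constant little, if at all, so that the step of a 1.1-fold lower number from compound 1 to compound 3 (0.04 log units; within the scatter) is estimated to stay within the scatter. Compound 3 is therefore expected to give about 110 nM in this assay, with a likely range from 40 nM to 350 nM.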

Compound 3, inhibition constant: 48 nM
Compound 3: middle estimate off by 2.3-fold (0.36 log units), on the high side, and the stated range covers the measured number.
By their numbers in this assay, from the lowest: compounds 2 and 3 (each within the scatter of the next); then compound 1.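

Exchanging methyl(methylsulfonyl)amino for (methylsulfonyl)methyl on an aromatic carbon of the ring of carbon only, meta to a large group, gives a 2.5-fold lower number from compound 1 to compound 3 (0.41 log units; beyond the scatter) in this assay and is a modest step. This position therefore responds to a change in the group it carries, and with the rest of compound 1 held constant, a substituent without nitrogen gives the lower number. Nothing measured here explains the difference between these two groups.

On these data alone, it remains open whether the methylsulfonyl part matters at this position, which a plain ethyl group or a methoxy group would test. As far as these compounds go, it is also open whether a longer chain, such as 2-(methylsulfonyl)ethyl, would extend or reverse the step seen here.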